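Series notes: varying the aniline-bearing aryloxy arm

The source may hold more compounds than are shown below. What is called first, only, known or untested is meant among the compounds shown, and "the series" means these compounds.

Measured so far:
compound 1 `Cc1c(F)c(Oc2cccc(N)c2)nc(Oc2cccc(C(=N)N)c2)c1F` — in an assay on isolated protein for inhibition of serine protease 1 (Bos taurus) (a lower number here means a stronger inhibitor, a higher number a weaker inhibitor), compound 1 gives > 5000 nM, a limit of the assay.
compound 2 `Cc1c(F)c(Oc2cccc(NS(C)(=O)=O)c2)nc(Oc2cccc(C(=N)N)c2)c1F` — in this assay compound 2 gives 1900 nM.
compound 3 `Cc1c(F)c(Oc2cccc(C(=N)N)c2)nc(Oc2cccc(C(=O)C(C)C)c2)c1F` — in this assay compound 3 gives 3800 nM.

Compound 1 stands at the floor of what is known here: it sits at the limit of > 5000 nM in this assay, at which 1 of the 3 values shown sits, so only a limit and no number exists for it. Compound 4 `Cc1c(Oc2nc(Oc3cccc(C(=N)N)c3)c(F)c(C)c2F)cccc1N(C)C` differs from compound 1 in one place: 3-(dimethylamino)-2-methylphenyl in place of 3-aminophenyl on an oxygen on an aromatic ring. For the measured compounds named here, no measured pair shows exactly this change, but two steps start from the same compound 1 and alter the same amino group. The step of an at least 2.6-fold lower number from compound 1 to compound 2 (0.42 log units; beyond the scatter) is at least modest; the step of an at least 1.3-fold lower number from compound 1 to compound 3 (0.11 log units; that floor lies within the scatter) has a floor within the scatter. Between compounds 2 and 3, a 2.0-fold higher number from compound 2 to compound 3 (0.30 log units; within the scatter) lies within the scatter. Both changes away from the free amino group of compound 1 give a number below its limit, and compound 4 likewise removes that free amino group. The expected step is therefore a lowering of about an at least 1.6-fold lower number from compound 1 to compound 4 (0.22 log units; that floor lies within the scatter), though since compound 1 is only a limit, the true size is uncertain. For compound 4 in this assay a value of 3000 nM is estimated, between 900 nM and 9000 nM.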

Compound 4, inhibition constant: 5000 nM
The estimate for compound 4 lay 1.7-fold (0.22 log units) below the measured number; low and high end bracket the measured number.
By their numbers in this assay, from the lowest: compounds 2, 3 and 4 (each within the scatter of the next, the first and the last beyond it).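

Compound 1 gives > 5000 nM, which is a limit of the assay. In this assay compound 4 gives 5000 nM, so this arm, with no free amino group, has a measured number. Compound 2 gives 1900 nM, and the scatter does not cover the gap between that value and the value of compound 4; among these compounds, removing the hydrogens of the free amino group is thus not enough on its own to match the methylsulfonyl change. The step is a number no higher from compound 1 to compound 4 (the limit leaves the size open), and its size cannot be read because the starting value is only a limit: the limit of > 5000 nM in this assay, at which 1 of the 4 values shown sits.

The entering 3-(dimethylamino)-2-methylphenyl differs from 3-aminophenyl in both the groups on the nitrogen and the methyl on the ring, and the compounds shown do not separate these two changes. A 3-(dimethylamino)phenyl arm and a 3-amino-2-methylphenyl arm would separate them, while an ethylsulfonyl group or an acetyl group on the nitrogen would test how far the number of compound 2 depends on the methylsulfonyl group itself.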